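A few compounds are considered here, and "the series" means these few. Any claim that something is new, unique, unknown or untested is made for them only; others in the source may bear on it.

Among the compounds at hand, compound 1, `Cc1cc(-c2cc(N3C[C@H](O)[C@@H](O)C3)ccc2O)nc(N)n1`, holds the only number: in a functional assay on EJ cells (Homo sapiens) for cytotoxicity, with a stated time of 48 h (a higher number here means a weaker inhibitor of growth, a lower number a stronger inhibitor of growth), compound 1 gives 900 nM. Within the data shown here, the entry for compound 2, `CN(C)c1cc(-c2cc(N3C[C@H](O)[C@@H](O)C3)ccc2O)nc(N)n1`, reads "not determined" (no result reported), so no measured step is available for comparison. Compound 3, `Nc1nc(-c2cc(N3C[C@H](O)[C@@H](O)C3)ccc2O)cc(C2CCCNC2)n1`, carries piperidin-3-yl in place of methyl on an aromatic carbon of the core of compound 1: piperidin-3-yl in place of methyl on an aromatic carbon. A modest move towards stronger growth inhibition is expected in this assay, though with little certainty, as an estimated step of a 2.0-fold lower number from compound 1 to compound 3 (0.30 log units; within the scatter). The expected value for compound 3 is 450 nM, with an estimated range of 90 nM to 2200 nM.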

Compound 3, concentration for 50% growth inhibition: > 10000 nM
Compound 3 ended at the assay's limit; the forecaster's own chance of this, stated with the estimate: 10%; middle value at least 22-fold (1.34 log units) away from the limit.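

Piperidin-3-yl in place of methyl on this aromatic carbon brings an at least 11-fold higher number from compound 1 to compound 3 (1.04 log units; beyond the scatter), so in this assay the position does not accept every group, and growth inhibition is lost with this change. Compound 3 stands at a limit of this assay, and the full size of the step stays unknown: the limit of > 10000 nM in this assay, at which 1 of the 3 values shown sits.

As far as these compounds go, whether the loss goes with the ring itself or with its nitrogen stays open. A cyclohexyl group on this carbon would separate the two, and an aminomethyl group would show whether a smaller amine behaves the same way.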